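The source may hold more compounds than are shown below. What is called first, only, known or untested is meant among the compounds shown, and "the series" means these compounds.

Of the compounds shown here, three of one series have been tested in a functional assay on MCF7 cells (Homo sapiens) for antiproliferative activity; on this read-out higher numbers stand for weaker inhibition and lower numbers for stronger inhibition. Compound 1, `COCOc1ccc(Cc2ccc3cc(NC(=O)c4ccc(OC(C)=O)c(CC=C(C)C)c4)c(=O)oc3c2C)cc1OC`, gives 14900 nM in this assay. Compound 2, `COc1cc(Cc2ccc3cc(NC(=O)c4ccc(O)c(CC=C(C)C)c4)c(=O)oc3c2C)ccc1O`, gives 14600 nM in this assay. Compound 3, `COCOc1ccc(Cc2ccc3cc(NC(=O)c4ccc(OC(C)=O)c(CC=C(C)C)c4)c(=O)oc3c2C)cc1`, gives 22700 nM in this assay. Compound 1 and compound 3 differ in one place: hydrogen in place of methoxy on an aromatic carbon. That change made a step of a 1.5-fold higher number from compound 1 to compound 3 (0.18 log units; within the scatter), so the two values lie close together. Compound 2 differs from compound 1 in more than one place, and the difference between the two cores is not broken down here; their values are nearly the same.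

Compound 4, `CC(C)=CCc1cc(C(=O)Nc2cc3ccc(Cc4ccc(O)cc4)c(C)c3oc2=O)ccc1O`, has not yet been measured in this assay. It differs from compound 2 by the same kind of change: hydrogen in place of methoxy on an aromatic carbon. The surroundings are not identical, however: in compound 1 the carbon that loses the methoxy is ortho to a methoxymethoxy group, while in compound 2 it is ortho to a hydroxy group; in both cases that carbon is meta to a large group. Because the earlier change produced only a 1.5-fold higher number from compound 1 to compound 3 (0.18 log units; within the scatter), this one is expected to give a step of about a 1.3-fold higher number from compound 2 to compound 4 (0.11 log units; within the scatter), with the outcome resting on that single precedent and therefore uncertain. Compound 4 is accordingly estimated at 19000 nM in this assay, expected to fall between 9000 nM and 40000 nM.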

Compound 4, half-maximal inhibitory concentration: 32100 nM
Compound 4: the middle estimate sits 1.7-fold (0.23 log units) below what was measured; the measured number falls inside the stated range.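

In this assay, putting hydrogen in place of methoxy on the core of compound 2 gave a 2.2-fold higher number from compound 2 to compound 4 (0.34 log units; beyond the scatter), a modest step that lies just beyond the scatter. The same change on the core of compound 1 stayed within the scatter, yet the two steps cannot be told apart: the same change on two cores in this assay, a 1.5-fold higher number (0.18 log units; within the scatter) from compound 1 to compound 3 and a 2.2-fold higher number (0.34 log units; beyond the scatter) from compound 2 to compound 4, 1.4-fold (0.16 log units) apart, within the scatter of two such steps. Among these compounds, on these two cores the change therefore carried over without a detectable difference in size, but this rests on only two pairs and does not show that the step would hold on a further core, nor does it explain why the number moves.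

The compounds shown leave open what other groups would do on this aromatic carbon, for instance an ethoxy group, a fluorine atom or an amine, and whether any of them would give a lower number than methoxy or hydrogen. They also leave open whether a larger step would appear with a carboxylic acid or a longer chain in place of the 4-hydroxy group of the 4-hydroxy-3-methoxybenzyl part, since every compound here carries oxygen on that carbon.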